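Swapping the Pyridine for Phenyl on a Syringol Scaffold

A few compounds are considered here, and "the series" means these few. Any claim that something is new, unique, unknown or untested is made for them only; others in the source may bear on it.

Compound 1: `COc1cc(CCc2ccccn2)cc(OC)c1O`, 660 nM
Compound 2: `COc1ccc(CCc2ccccn2)cc1OC`, 11100 nM

Of the compounds shown here, two have been measured in a functional assay on MKN-45 cells (Homo sapiens) for antiproliferative activity, read by MTT assay, with a stated time of 72 h; a lower number here means a stronger inhibitor, a higher number a weaker inhibitor. Compound 1 gives 660 nM, the lowest of the two numbers. Compound 2 gives 11100 nM, a markedly higher number, so compound 1 stands clearly ahead of it. Among the measured compounds shown here, these two differ in several places at once, so their pair shows no single step.

The next compound is compound 3 `COc1cc(CCc2ccccc2)cc(OC)c1O`, not yet measured. It departs from compound 1 by one change: phenyl in place of pyridin-2-yl on a saturated chain carbon, two bonds along the chain from an aromatic carbon. For the measured compounds named here, no measured pair shows this change, so its effect is unknown. Because compound 1 gives 660 nM with the pyridine present, a moderate weakening is expected when the nitrogen is lost, giving an estimated step of a 2.3-fold higher number from compound 1 to compound 3 (0.36 log units; beyond the scatter). Compound 3 is thus expected at about 1500 nM, within a range of 400 nM to 6000 nM.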

Compound 3, half-maximal inhibitory concentration: 1040 nM
Beside the measured number, compound 3's estimate is 1.4-fold (0.16 log units) above it, within the range that was stated.
By their numbers in this assay, from the lowest: compounds 1 and 3 (each within the scatter of the next); then compound 2.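

In this assay the exchange of pyridin-2-yl for phenyl gives a 1.6-fold higher number from compound 1 to compound 3 (0.20 log units; within the scatter), so the two compounds cannot be told apart in this assay. Among the compounds shown here, this is the first single change seen at this place on the core of compound 1, and it shows that the ring can lose its nitrogen, and with it the hydrogen-bond acceptor counted for pyridin-2-yl, without a change in the number that stands beyond the scatter. Nothing measured here explains why the two rings read so alike.

Still open, going by these compounds, is whether an amine or a carboxylic acid placed on the phenyl ring of compound 3 would move the number beyond the scatter. Also open, on these data alone, is how a longer chain carrying the same ring would read in this assay.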